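Cyclohexyl-to-phenyl swap on the piperidine series, second pair

The compounds below may be only part of what the source reports. "The series", "measured", "known", "first", "only" and "open" are said of these compounds alone.

Three compounds of this series have been run in a functional assay on WiDr cells (Homo sapiens) for antiproliferative activity, read by sulforhodamine B assay, with a stated time of 48 h; a higher number here means a weaker inhibitor of growth, a lower number a stronger inhibitor of growth. Compound 1 `Cc1ccc(S(=O)(=O)N2CC[C@@H](Cl)C[C@@H]2C2CCCCC2)cc1` gives 15000 nM. Compound 2 `Cc1ccc(S(=O)(=O)N2CC[C@@H](Cl)C[C@@H]2c2ccccc2)cc1` gives 37000 nM. Compound 3 `Cc1ccc(S(=O)(=O)N2CCC(Br)=CC2C2CCCCC2)cc1` gives 18000 nM. Compound 1 and compound 3 stand within the scatter of each other; compound 2 and compound 3 do not, the number for compound 2 being the higher of the two.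

The change from compound 1 to compound 2 is phenyl in place of cyclohexyl on a saturated ring carbon, and it produced a 2.5-fold higher number from compound 1 to compound 2 (0.39 log units; beyond the scatter). The same kind of change takes compound 3 to compound 4 `Cc1ccc(S(=O)(=O)N2CCC(Br)=CC2c2ccccc2)cc1`: phenyl in place of cyclohexyl on a saturated ring carbon. The two place descriptions differ in one respect: in the first pair the altered carbon is two ring bonds from the ring atom that bears a chloro group, in the second it is two ring bonds from the ring atom that bears a bromo group. The difference between the core of compound 1 and the core of compound 3 is not broken down here.

Among the measured compounds shown here, with only one earlier instance of this kind of change to go on, the expectation for compound 4 is that it moves as compound 2 did from compound 1, that is an estimated 2.5-fold higher number from compound 3 to compound 4 (0.40 log units; beyond the scatter), resting on a 2.5-fold higher number from compound 1 to compound 2 (0.39 log units; beyond the scatter) and on compound 3 giving 18000 nM. Compound 4 is therefore expected to give 45000 nM in this assay, with the estimate bounded between 20000 nM and 100000 nM.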

Compound 4, concentration for 50% growth inhibition: 29000 nM
Compound 4: middle estimate off by 1.6-fold (0.19 log units), on the high side; the measured number falls inside the stated range.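

In this assay the swap of cyclohexyl for phenyl on the second core gives a 1.6-fold higher number from compound 3 to compound 4 (0.21 log units; within the scatter), so on this core the swap alone cannot be told apart from repeat-to-repeat variation. Set beside the first instance, the step on the second core does not differ measurably, and the swap carries over between these two cores with no detectable dependence on the core: the same change on two cores in this assay, a 2.5-fold higher number (0.39 log units; beyond the scatter) from compound 1 to compound 2 and a 1.6-fold higher number (0.21 log units; within the scatter) from compound 3 to compound 4, 1.5-fold (0.18 log units) apart, within the scatter of two such steps. Among the compounds shown here, this rests on two matched pairs only; it does not fix the size of the step, does not show that the swap would behave alike on any further core, and says nothing of why the numbers fall where they do, while the first pair lies beyond the scatter and the second within it, so a consistent penalty for phenyl remains a reading of the first pair that the second neither confirms nor contradicts.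

Still open is how the series responds to a pyridyl ring or a straight hexyl chain on the same saturated ring carbon, where only cyclohexyl and phenyl appear among the compounds shown. Also open, as far as these compounds go, is whether an amine or a hydroxyl in place of the chloro or bromo group would alter the step seen with this swap.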